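Coumarin-linked pyrazole ethers: para-chloro replaces difluoro

This account rests on a few compounds, and the source may have more. Where it says the series, first, only, none or still open, it means among the compounds named here.

Measured compounds:
- compound 1 `Cc1ccc(Oc2c(/C=N\CCCCCOc3cc4oc(=O)cc(C)c4cc3Cl)c(C)nn2C)cc1`: 10300 nM
- compound 2 `Cc1nn(C)c(Oc2cccc(F)c2F)c1/C=N\CCCCCCOc1cc2oc(=O)cc(C)c2cc1Cl`: > 25000 nM

Two compounds share the chlorinated coumarin core joined through an oxygen-bearing alkyl chain and an imine to the pyrazole ether. In a functional assay on HepG2 cells (Homo sapiens) for antiproliferative activity, read by MTT assay, with a stated time of 72 h (on this read-out higher numbers stand for weaker inhibition and lower numbers for stronger inhibition), compound 1 gives 10300 nM and sits at the weak end. For compound 2 the result in this assay is only a limit, > 25000 nM, so no number is known. Among the measured compounds shown here, this is the situation described by the limit of > 25000 nM in this assay, at which 1 of the 2 values shown sits: one of the two values is a limit, and no step between measured compounds can be stated.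

Compound 3 `Cc1nn(C)c(Oc2ccc(Cl)cc2)c1/C=N\CCCCCCOc1cc2oc(=O)cc(C)c2cc1Cl` keeps the six-carbon chain of compound 2 and changes the aryl ether: 4-chlorophenyl in place of 2,3-difluorophenyl on an oxygen on an aromatic ring. A para-substituted phenoxy group is also present in compound 1, which gives a number rather than a limit, so for compound 3 a readable, weak inhibition is expected.

The expected step from compound 2 to compound 3 in this assay is an at least 1.6-fold lower number from compound 2 to compound 3 (0.22 log units; that floor lies within the scatter), toward a lower number, though against a limit its true size is uncertain.

Compound 3 is estimated at 15000 nM in this assay, within 5000 nM to 40000 nM.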

Compound 3, half-maximal inhibitory concentration: 2960 nM
The estimate for compound 3 lay 5.1-fold (0.70 log units) above the measured number, and the stated range ends above it.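

On the oxygen on an aromatic ring, with the chain and the shared core unchanged, 4-chlorophenyl in place of 2,3-difluorophenyl turns a result without a number into a readable one: in this assay the change gives an at least 8.4-fold lower number from compound 2 to compound 3 (0.92 log units; beyond the scatter). Among the compounds shown here, this is the first comparison that differs in one place only, and it shows that the aryl group on this oxygen matters for the read-out in this assay, by a margin beyond the scatter. The value of compound 2 is a limit and not a number, so the step is a floor and its true size remains unknown: the limit of > 25000 nM in this assay, at which 1 of the 3 values shown sits.

The compounds shown cannot separate the effect of adding the chlorine from that of losing the two fluorines, and a plain phenyl group or a single fluorine on the same ring would be needed to tell these apart. Also open, from the compounds shown here alone, is how the chain contributes, as compound 1 and compound 3 differ in more than one place, and how a ring bearing an amine or a carboxylic acid would read at this position.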